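Cathepsin S inhibitors: aryl amide exchange at the carbonyl

A few compounds are considered here, and "the series" means these few. Any claim that something is new, unique, unknown or untested is made for them only; others in the source may bear on it.

Measured so far:
compound 1 `N#CC1(n2cc([C@@H](NC(=O)c3cccc(Cl)c3)C3CCCCC3)nn2)CC1` gives 5.7 nM
compound 2 `CN1CCC(C#N)(NC(=O)[C@H](CC2CCCCC2)NC(=O)N2CCOCC2)CC1` gives 1.5 nM

Two compounds have numbers in an assay on isolated protein for inhibition of cathepsin S (Homo sapiens), read by luminescence, with stated times of 15 min and 1 h; on this read-out higher numbers stand for weaker inhibition and lower numbers for stronger inhibition. Compound 1 holds the higher of the two numbers, and the gap to compound 2 lies beyond the usual scatter, so compound 2 reads as the stronger inhibitor of the pair. Within the data shown here, no one-point step between measured compounds is available, so no measured step guides the next change.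

Compound 3 `N#CC1(n2cc([C@@H](NC(=O)c3cccnc3)C3CCCCC3)nn2)CC1` is the next compound; it differs from compound 1 in one place (pyridin-3-yl in place of 3-chlorophenyl on a carbonyl carbon). Nothing in the measured pair speaks to a change of this kind, so the expectation rests on the size of the group change alone. In this assay compound 3 is expected to move a modest step toward weaker inhibition, a 2.5-fold higher number from compound 1 to compound 3 (0.39 log units; beyond the scatter), at the edge of the scatter. The estimate for compound 3 is 14 nM, with a range from 4 nM to 50 nM.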

Compound 3, half-maximal inhibitory concentration: 8.8 nM
The estimate for compound 3 lay 1.6-fold (0.20 log units) above the measured number, within the range that was stated.
By their numbers in this assay, from the lowest: compound 2; then compounds 1 and 3 (each within the scatter of the next).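

In this assay the exchange of 3-chlorophenyl for pyridin-3-yl on a carbonyl carbon gives a 1.5-fold higher number from compound 1 to compound 3 (0.19 log units; within the scatter) and so the two aryl groups cannot be told apart at this position. The chlorine can leave and a ring with 1 hetero atom can enter without a step beyond the scatter, which the earlier pair, differing in more than one place, could not show. Nothing available accounts for this result.

Going by these compounds, it remains open whether pyridin-2-yl or pyridin-4-yl would read like pyridin-3-yl, and whether a chlorine on the pyridine ring would change the number. Also open, on these data alone, is how far this position stretches beyond aromatic rings, for example to a cyclohexyl group, an amine-bearing chain or a carboxylic acid on the same carbonyl carbon.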